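The source may report more compounds than this note shows. Statements on the series, on what has been measured and on what is new or still open speak of the compounds shown alone.

In an ADME assay on Vero cells (Chlorocebus sabaeus) for cytotoxicity (a lower number here means that less compound is tolerated, a higher number that more compound is tolerated), compound 3 `C[C@]1(CO)O[C@@H](n2cc(-c3ccsc3)c3c(N)ncnc32)[C@H](O)[C@@H]1O` gives > 50000 nM, which is a limit of the assay and not a number. Compound 2 `C[C@]1(CO)O[C@@H](n2cc(-c3cccs3)c3c(N)ncnc32)[C@H](O)[C@@H]1O` gives > 50000 nM, also a limit. Compound 1 `C[C@]1(CO)O[C@@H](n2cc(I)c3c(N)ncnc32)[C@H](O)[C@@H]1O`, with iodo where those two carry a thiophene ring, gives 8080 nM.

The next compound, compound 4 `C#Cc1cn([C@@H]2O[C@](C)(CO)[C@@H](O)[C@H]2O)c2ncnc(N)c12`, keeps the shared core and changes one group: ethynyl in place of thiophen-3-yl on an aromatic carbon. In words, ethynyl comes in place of thiophen-3-yl on an aromatic carbon.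

Among the compounds with values here, two measured steps bear on this: an at least 6.1-fold higher number from compound 1 to compound 2 (0.79 log units; beyond the scatter) and an at least 6.1-fold higher number from compound 1 to compound 3 (0.79 log units; beyond the scatter). Both lie beyond the scatter, and both give only a minimum size. Like compound 1, compound 4 has no thiophene ring, so those steps run backwards here, and a modest move to a lower number is expected in this assay. Iodo and ethynyl are different groups, so this guide is loose.

The estimated change is an at least 4.1-fold lower number from compound 3 to compound 4 (0.61 log units; beyond the scatter). For compound 4 the expected value is 12000 nM, within an estimated range from 2500 nM to 50000 nM.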

Compound 4, half-maximal cytotoxic concentration: 13400 nM
Compound 4: the middle estimate sits 1.1-fold (0.05 log units) below what was measured; the measured number falls inside the stated range.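

In this assay, ethynyl on this aromatic carbon gives an at least 3.7-fold lower number from compound 3 to compound 4 (0.57 log units; beyond the scatter), and it gives an at least 3.7-fold lower number from compound 2 to compound 4 (0.57 log units; beyond the scatter), so the step appears with either thiophene as the starting group. Compound 2 and compound 3 each stand at a limit of the assay rather than at a number, and for that reason both steps give only a minimum size: the limit of > 50000 nM in this assay, at which 2 of the 4 values shown sit.

The new comparison with iodo, a 1.7-fold higher number from compound 1 to compound 4 (0.22 log units; within the scatter), lies within the scatter, so among the compounds shown, the two without a ring at this position cannot be told apart, while the two thiophenes stand apart from both.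

The step between the two thiophenes cannot be read, and neither can their true values. On these data alone, it also remains open whether a phenyl ring or an aminomethyl group here would behave like the thiophenes or like ethynyl.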